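Dichlorophenyl for Bromophenyl on a Longer Chain

This account rests on a few compounds, and the source may have more. Where it says the series, first, only, none or still open, it means among the compounds named here.

The study compares four related compounds in a functional assay on PC-12 cells (Rattus norvegicus) for cytotoxicity, read by MTT assay, with stated times of 3 h and 2 h, tested at 0.1 uM; a higher number here means a stronger effect of the compound at the concentration tested, a lower number a weaker effect. Compound 1 `O=C(CCCCC1CCSS1)NCc1cn(CCCOc2ccc3cc(-c4ccc(Br)cc4)c(=O)oc3c2)nn1` gives 39.5% in this assay. Compound 2 `O=C(CCCCC1CCSS1)NCc1cn(CCCOc2ccc3cc(-c4ccc(Cl)c(Cl)c4)c(=O)oc3c2)nn1` carries the change (3,4-dichlorophenyl in place of 4-bromophenyl on an aromatic carbon), and in this assay compound 2 gives 38.1%. The step that this change made is a number 1.4 percentage points lower from compound 1 to compound 2 (within the scatter).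

Compound 3 `O=C(CCCCC1CCSS1)NCc1cn(CCCCCOc2ccc3cc(-c4ccc(Br)cc4)c(=O)oc3c2)nn1` is built on a different core from compound 1; the difference between the two cores is not broken down here. In this assay compound 3 gives 41.8%, which stands within the scatter of both compound 1 and compound 2.

Compound 4 `O=C(CCCCC1CCSS1)NCc1cn(CCCCCOc2ccc3cc(-c4ccc(Cl)c(Cl)c4)c(=O)oc3c2)nn1` has not yet been measured. Among the compounds with values here, it differs from compound 3 by 3,4-dichlorophenyl in place of 4-bromophenyl on an aromatic carbon, the same kind of change as the one from compound 1 to compound 2, made at a place that reads the same in both pairs. Since the earlier step was within the scatter, the writer expects for compound 4 a step of about a number 1.3 percentage points lower from compound 3 to compound 4 (within the scatter) from compound 3 in this assay, resting on the step of a number 1.4 percentage points lower from compound 1 to compound 2 (within the scatter). The estimate for compound 4 in this assay is therefore 40.5%, expected to fall between 33% and 48%. The measured number for compound 4 will show whether this expectation holds.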

Compound 4, a percentage reported as activity, at one concentration (the size of the read-out at that concentration, not a potency): 39.7%
Estimate against measurement, compound 4: 0.8 percentage points above; the measured number falls inside the stated range.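

Carried to the core of compound 3, 3,4-dichlorophenyl in place of 4-bromophenyl gives in this assay a number 2.1 percentage points lower from compound 3 to compound 4 (within the scatter). Set beside the earlier step, the change reads alike on the two cores: the same change on two cores in this assay, a number 1.4 percentage points lower (within the scatter) from compound 1 to compound 2 and a number 2.1 percentage points lower (within the scatter) from compound 3 to compound 4, 0.7 percentage points apart, within the scatter of two such steps. Within the data shown here, this shows that, in these two pairs, the swap of one halogenated phenyl for the other leaves the read-out where it was on either core, but it does not show that the change has any effect of its own, since neither step stands clear of the scatter, and a match between two such small steps is weak evidence of a transferable effect; it also rests on only two pairs and on one concentration, which gives the size of the read-out there and not a potency.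

The compounds shown leave open whether a substituent of another kind on this phenyl ring, such as an amine, a carboxylic acid or a nitrile, would produce a step that stands beyond the scatter. They also leave open whether the same swap would read alike on a core with a longer chain than those of compound 3 and compound 4.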